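This account rests on a few compounds, and the source may have more. Where it says the series, first, only, none or still open, it means among the compounds named here.

Series notes. Compound 1 `COc1ccc(F)cc1CNCCCNc1ccnc2cc(Oc3ccc(Cl)cc3)ccc12` gives 317 10^-6 cm/s in an ADME assay for permeability, using PAMPA, with a stated time of 30 min, at pH 7.4; a lower number here means that the compound crosses the layer more slowly, a higher number that the compound crosses the layer faster. Compound 2 `COc1ccc(F)cc1CNCCCNc1ccnc2cc(-c3cccc4ccccc34)ccc12` gives 237 10^-6 cm/s in this assay, and compound 3 `COc1cccc(CNCCCNc2ccnc3cc(-c4cccc5ccccc45)ccc23)c1O` gives 237 10^-6 cm/s in this assay. The step of a 1.3-fold higher number from compound 2 to compound 1 (0.13 log units; within the scatter) corresponds to the change (4-chlorophenoxy in place of naphthalen-1-yl on an aromatic carbon). The step of no change at the digits printed from compound 2 to compound 3 (within the scatter) corresponds to the change (2-hydroxy-3-methoxyphenyl in place of 5-fluoro-2-methoxyphenyl on a saturated chain carbon bound to an amine nitrogen), which is also how the core of compound 3 differs from that of compound 2.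

Compound 4 `COc1cccc(CNCCCNc2ccnc3cc(Oc4ccc(Cl)cc4)ccc23)c1O` has not yet been measured in this assay. It differs from compound 3 by 4-chlorophenoxy in place of naphthalen-1-yl on an aromatic carbon, the same change as from compound 2 to compound 1, made on the core of compound 3. Because the step of a 1.3-fold higher number from compound 2 to compound 1 (0.13 log units; within the scatter) was within the scatter, a similar step is expected here, a 1.3-fold higher number from compound 3 to compound 4 (0.10 log units; within the scatter). Compound 4 is accordingly estimated at 300 10^-6 cm/s in this assay, within the range 180 10^-6 cm/s to 450 10^-6 cm/s.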

Compound 4, apparent permeability: 317 10^-6 cm/s
Estimate against measurement, compound 4: 1.1-fold (0.02 log units) below, within the range that was stated.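

In this assay, 4-chlorophenoxy in place of naphthalen-1-yl gives a 1.3-fold higher number from compound 3 to compound 4 (0.13 log units; within the scatter), and this change carries across the two cores: the same change on two cores in this assay, a 1.3-fold higher number (0.13 log units; within the scatter) from compound 2 to compound 1 and a 1.3-fold higher number (0.13 log units; within the scatter) from compound 3 to compound 4, 1.0-fold (0.00 log units) apart, within the scatter of two such steps
2-Hydroxy-3-methoxyphenyl in place of 5-fluoro-2-methoxyphenyl gives no change at the digits printed from compound 1 to compound 4 (within the scatter), and this change also carries across: the same change on two cores in this assay, no change at the digits printed (within the scatter) from compound 2 to compound 3 and no change at the digits printed (within the scatter) from compound 1 to compound 4, 1.0-fold (0.00 log units) apart, within the scatter of two such steps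
For the compounds shown here, all of these steps lie within the scatter, so the agreement shows only that neither change has a detectable effect on these two cores; it does not show a real shift being transferred, nor that the same would hold on other cores.

Open, as far as these compounds go, is whether a carboxylic acid or an amine in place of 4-chlorophenoxy would give a step beyond the scatter in this assay. The same question stands for a longer chain linking the two amine nitrogens.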